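The source may report more compounds than this note shows. Statements on the series, on what has been measured and on what is new or still open speak of the compounds shown alone.

Measured so far:
compound 1, `O=C(Nc1cccc(-n2cc(-c3ccncc3)c(-c3ccc(Cl)c(O)c3)n2)c1)Nc1cccc(C(F)(F)F)c1`, 23800 nM
compound 2, `COc1cc(-c2nn(-c3cccc(NC(=O)Nc4ccc(Cl)c(Cl)c4)c3)cc2-c2ccncc2)ccc1Cl`, 1720 nM

Both were tested in a functional assay on COLO 205 cells (Homo sapiens) for inhibition, read by sulforhodamine B assay, with a stated time of 48 h; on this read-out higher numbers stand for weaker inhibition of growth and lower numbers for stronger inhibition of growth. Compound 2 carries the lowest of the two numbers; its nearest neighbour, compound 1, gives a markedly higher one, a gap that lies beyond the scatter. The two differ in two places, so no single change can be read from that gap.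

Compound 3, `O=C(Nc1cccc(-n2cc(-c3ccncc3)c(-c3ccc(Cl)c(O)c3)n2)c1)Nc1ccc(Cl)c(Cl)c1`, has not yet been measured. It follows from compound 2 by a single change: hydrogen in place of methyl on an oxygen on an aromatic ring. Going by the values given here, no measured pair shows this change on its own, so its size can only be guessed. He expects the number to move upward, by a modest step that may or may not exceed the scatter, since compound 1, which also carries the hydroxy, gives 23800 nM. For compound 3 the estimate is 4000 nM, in the range 1000 nM to 16000 nM, a step of a 2.3-fold higher number from compound 2 to compound 3 (0.37 log units; beyond the scatter) that is expected rather than known.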

Compound 3, concentration for total growth inhibition: 9490 nM
Compound 3: the middle estimate sits 2.4-fold (0.38 log units) below what was measured, and the stated range covers the measured number.
By their numbers in this assay, from the lowest: compound 2; then compound 3; then compound 1.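

In this assay, the change from methoxy to hydroxy on the aromatic ring can now be read on its own: a 5.5-fold higher number from compound 2 to compound 3 (0.74 log units; beyond the scatter), a shift towards weaker inhibition of growth. Compound 3 also isolates the second place in which compound 1 and compound 2 differ, as 3,4-dichlorophenyl in place of 3-(trifluoromethyl)phenyl on an amide-type nitrogen gives a 2.5-fold lower number from compound 1 to compound 3 (0.40 log units; beyond the scatter), a shift towards stronger inhibition of growth, so each place has a step of its own beyond the scatter. The data offer no measured explanation for either step.

The compounds shown leave open whether the methoxy-to-hydroxy step would keep its size with 3-(trifluoromethyl)phenyl on the amide-type nitrogen. They also leave open how an ethoxy group, with its longer chain on that oxygen, or an amine in place of the methoxy would read in this assay.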